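A Methylsulfanyl Swap Where Every Measured Value Is a Limit

The source may hold more compounds than are shown below. What is called first, only, known or untested is meant among the compounds shown, and "the series" means these compounds.

Compound 1 `CN(C)c1ncnc2c1c(-c1ccsc1)cn2[C@@H]1O[C@H](CO)[C@@H](O)[C@H]1O` is the starting point. In a functional assay on HepG2 cells (Homo sapiens) for antiproliferative activity, read by XTT assay, with a stated time of 72 h (a lower number here means a stronger inhibitor, a higher number a weaker inhibitor), compound 1 gives > 20000 nM, which is a limit of the assay rather than a measured number. Two neighbours share its core. Compound 2 `CN(C)c1ncnc2c1c(-c1cccs1)cn2[C@@H]1O[C@H](CO)[C@@H](O)[C@H]1O` carries thiophen-2-yl in place of thiophen-3-yl on an aromatic carbon, and in this assay compound 2 gives > 20000 nM, again a limit. Compound 3 `CN(C)c1ncnc2c1c(-c1cc3ccccc3o1)cn2[C@@H]1O[C@H](CO)[C@@H](O)[C@H]1O` carries 1-benzofuran-2-yl in place of thiophen-3-yl on an aromatic carbon, and compound 3 gives > 20000 nM, also a limit. The steps a step that the two limits leave unreadable from compound 1 to compound 2, a step that the two limits leave unreadable from compound 1 to compound 3 and a step that the two limits leave unreadable from compound 2 to compound 3 therefore cannot be sized, as the limit of > 20000 nM in this assay, at which 3 of the 3 values shown sit, shows.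

Compound 4 `CSc1ncnc2c1c(-c1ccsc1)cn2[C@@H]1O[C@H](CO)[C@@H](O)[C@H]1O` differs from compound 1 by methylsulfanyl in place of dimethylamino on an aromatic carbon. For the measured compounds named here, none of the measured steps touches this part of the core, so they give no direction; the only guidance is that every value so far sits at the limit. Compound 4 is therefore expected to behave alike, with an estimated step of a number no higher from compound 1 to compound 4 (the limit leaves the size open). The estimated value for compound 4 is 20000 nM, within 8000 nM to 50000 nM, and most likely it will again be reported only as a limit.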

Compound 4, half-maximal inhibitory concentration: > 15000 nM
Compound 4: only a limit was reported; the forecaster's own chance of this, stated with the estimate: 75%; the middle value lies beyond the limit too.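

Compound 1 and compound 4 are both reported only as limits in this assay, and the step between them cannot be read. The compounds shown leave open how strongly any of them acts in this assay, and whether methylsulfanyl or dimethylamino is the better group there.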